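This account rests on a few compounds, and the source may have more. Where it says the series, first, only, none or still open, it means among the compounds named here.

In a toxicity assay on THP-1 cells (Homo sapiens) for inhibition (on this read-out lower numbers stand for higher toxicity in this test and higher numbers for lower toxicity in this test), compound 2 `Cn1c(-c2ccc(C#N)cc2)cnc1NC(=O)c1ccc(F)cc1` stands only at a limit, > 50000 nM. Compound 3 `Cn1c(-c2ccccc2Br)cnc1NC(=O)c1ccc(F)cc1` differs from it in one place: 2-bromophenyl in place of 4-cyanophenyl on an aromatic carbon. Compound 1 `Cn1c(-c2ccc(Cl)cc2)cnc1NC(=O)c1ccc(F)cc1`, which carries chloro rather than cyano on its phenyl ring, gives 37000 nM. Within the data shown here, the one measured step that bears on this change is an at least 1.3-fold higher number from compound 1 to compound 2 (0.13 log units; that floor lies within the scatter), and it gives only a floor that lies within the scatter. Among the measured compounds shown here, with that step as the sole guide, a modest move to a lower number is expected: an at least 1.6-fold lower number from compound 2 to compound 3 (0.22 log units; that floor lies within the scatter). Compound 3 is estimated at 30000 nM, with an expected range of 12000 nM to 60000 nM.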

Compound 3, half-maximal cytotoxic concentration: > 100000 nM
Compound 3: no number, only a limit; the forecaster's own chance of this, stated with the estimate: 30%; at least 3.3-fold (0.52 log units) between middle value and limit.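

Among these compounds, replacing 4-chlorophenyl with 2-bromophenyl gives an at least 2.7-fold higher number from compound 1 to compound 3 (0.43 log units; beyond the scatter), the first step at this position that lies beyond the scatter, in the direction of lower toxicity in this test. Compound 2 and compound 3 both stand at limits, so the step between them cannot be read.

As far as these compounds go, whether the halogen or its place on the phenyl ring matters more stays open, and a 2-chlorophenyl or 4-bromophenyl group at this carbon would separate the two. From the compounds shown here alone, how a phenyl ring carrying an amine would read is also open.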